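Replacing an aryl group with hydroxyethyl on the triazole

The source may hold more compounds than are shown below. What is called first, only, known or untested is meant among the compounds shown, and "the series" means these compounds.

The study compares two compounds that share a common core and differ mainly in what is attached to the five-membered ring. Compound 1, `Cc1ccc(-c2cn(-c3ccc(CN4CCCCC4)cc3)nn2)cc1Nc1nccc(-c2cccnc2)n1`, carries a methylphenyl group on that ring and a piperidinylmethylphenyl group on the ring nitrogen. In a functional assay on HL-60 cells (Homo sapiens) for inhibition, read by MTT assay, with a stated time of 72 h (on this read-out higher numbers stand for weaker inhibition and lower numbers for stronger inhibition), compound 1 gives 740 nM. Compound 2, `Cc1ccc(-n2cc(-c3ccc(C)c(C(F)(F)F)c3)nn2)cc1Nc1nccc(-c2cccnc2)n1`, bears a 4-methyl-3-(trifluoromethyl)phenyl group on the ring carbon instead. In this assay compound 2 reaches only a limit, > 30000 nM, and so stands at the limit of > 30000 nM in this assay, at which 1 of the 2 values shown sits, among the two values shown; its exact potency is not known.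

Compound 3, `Cc1ccc(-n2cc(CCO)nn2)cc1Nc1nccc(-c2cccnc2)n1`, has not yet been measured. It differs from compound 2 by one change: 2-hydroxyethyl in place of 4-methyl-3-(trifluoromethyl)phenyl on an aromatic carbon. For the measured compounds named here, no measured pair differs by exactly this change, so the size of the step is uncertain. Compound 2 sits at the limit and compound 1, which differs in more than one place, sits far from it, so the step is expected to bring compound 3 toward stronger inhibition. For compound 3 in this assay the estimate is 6000 nM, with a range from 1200 nM to 30000 nM. The corresponding step of an at least 5.0-fold lower number from compound 2 to compound 3 (0.69 log units; beyond the scatter) is an expectation, not a measurement.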

Compound 3, half-maximal inhibitory concentration: 9100 nM
Estimate against measurement, compound 3: 1.5-fold (0.18 log units) below; the measured number falls inside the stated range.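

Putting 2-hydroxyethyl in place of 4-methyl-3-(trifluoromethyl)phenyl on the aromatic carbon of the five-membered ring moves the read-out in this assay by a step beyond the scatter (an at least 3.2-fold lower number from compound 2 to compound 3 (0.51 log units; beyond the scatter)). This position therefore does not need an aromatic ring for a measurable value in this assay, and the short chain, with its hydrogen-bond donor and acceptor, gives a lower number than the larger aryl group it replaces. Only a lower bound on the step can be given, and the value of compound 2 is a limit, not a number: the limit of > 30000 nM in this assay, at which 1 of the 3 values shown sits.

The compounds shown leave open whether the lower number comes from the hydroxyl group or simply from the loss of the aryl group, a question that a plain ethyl chain on this carbon would address. They also leave open how the read-out responds to a longer chain, an amine or a carboxylic acid at this position, so no trend along this position can be drawn from one step.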